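Phenyl in Place of Methyl: Expected Effect on Binding

The compounds below may be only part of what the source reports. "The series", "measured", "known", "first", "only" and "open" are said of these compounds alone.

Measured so far in an assay on membranes from brain (Cavia porcellus) for binding affinity to Sigma non-opioid intracellular receptor 1 (Homo sapiens), read by radioligand binding; a higher number here means a weaker inhibitor, a lower number a stronger inhibitor:
compound 1, `CN(C(=N)Nc1cccc2ccccc12)c1cccc2ccccc12`, gives 4800 nM
compound 2, `N=C(Nc1cccc2ccccc12)N(c1ccccc1)c1cccc2ccccc12`, gives 7930 nM
compound 3, `CN(C(=N)N(C)c1cccc2ccccc12)c1cccc2ccccc12`, gives 10700 nM

Compound 3 has the highest number of the three in this assay, that is the weakest binding seen here. Its nearest neighbour is compound 2, whose value lies within the scatter of compound 3, so no order between those two can be claimed. The step of a 2.2-fold higher number from compound 1 to compound 3 (0.35 log units; beyond the scatter) is modest but beyond the scatter.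

Compound 4, `CN(C(=N)N(c1ccccc1)c1cccc2ccccc12)c1cccc2ccccc12`, is the next compound. The change from compound 3 is phenyl in place of methyl on a nitrogen on an aromatic ring. The same change has been made once before among the measured compounds: the step of a 1.7-fold higher number from compound 1 to compound 2 (0.22 log units; within the scatter), which stayed within the scatter. Among the measured compounds shown here, the only measured precedent therefore points to little or no movement, at most a slight drift to a higher number in this assay.

Compound 4 is thus expected to give about 15000 nM in this assay, with a likely range from 6000 nM to 40000 nM. The expected step of a 1.4-fold higher number from compound 3 to compound 4 (0.15 log units; within the scatter) is not expected to exceed the usual scatter.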

Compound 4, half-maximal inhibitory concentration: 11000 nM
Compound 4: middle estimate off by 1.4-fold (0.13 log units), on the high side; the measured number falls inside the stated range.
By their numbers in this assay, from the lowest: compounds 1, 2, 3 and 4 (each within the scatter of the next, the first and the last beyond it).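

In this assay, phenyl in place of methyl on this nitrogen now gives a 1.0-fold higher number from compound 3 to compound 4 (0.01 log units; within the scatter), so this change has been read on two cores and stayed within the scatter on both: the same change on two cores in this assay, a 1.7-fold higher number (0.22 log units; within the scatter) from compound 1 to compound 2 and a 1.0-fold higher number (0.01 log units; within the scatter) from compound 3 to compound 4, 1.6-fold (0.21 log units) apart, within the scatter of two such steps

Methyl in place of hydrogen gives a 1.4-fold higher number from compound 2 to compound 4 (0.14 log units; within the scatter), which stays within the scatter although the same change went beyond it on the core of compound 1, and the two steps still cannot be told apart: the same change on two cores in this assay, a 2.2-fold higher number (0.35 log units; beyond the scatter) from compound 1 to compound 3 and a 1.4-fold higher number (0.14 log units; within the scatter) from compound 2 to compound 4, 1.6-fold (0.21 log units) apart, within the scatter of two such steps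

Phenyl in place of hydrogen gives a 2.3-fold higher number from compound 1 to compound 4 (0.36 log units; beyond the scatter), so even this change of group costs only a modest step.

The compounds shown leave open whether a longer chain, such as propyl, or a chain ending in an amine or a carboxylic acid would move the number further at this place. They also leave open what a methoxy group on the entering phenyl would do.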